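Swapping an aryl group on an imidazole nitrogen

The compounds below may be only part of what the source reports. "The series", "measured", "known", "first", "only" and "open" are said of these compounds alone.

Measured so far:
- compound 1, `Cc1cc2occ(-c3nc(-c4ccccc4)c(-c4ccccc4)n3-c3ccc([N+](=O)[O-])cc3)c(=O)c2cc1Cl`: > 100000 nM
- compound 2, `Cc1cccc(-n2c(-c3coc4cc(C)c(Cl)cc4c3=O)nc(-c3ccccc3)c2-c2ccccc2)c1`: "not determined" (no result reported)

In an ADME assay on MCF-10A cells (Homo sapiens) for cytotoxicity, read by MTT assay, with a stated time of 72 h (on this read-out lower numbers stand for stronger inhibition and higher numbers for weaker inhibition), compound 1 reaches only a limit of the assay, > 100000 nM, rather than a number. For the measured compounds named here, compound 2 has no result in this assay, so it stands at no value at all; the one value shown beside it is the limit described by the limit of > 100000 nM in this assay, at which 1 of the 2 values shown sits. The step of interest goes from compound 2 to compound 3, `Cc1cc2occ(-c3nc(-c4ccccc4)c(-c4ccccc4)n3-c3ccc(Cl)cc3)c(=O)c2cc1Cl`, which is not yet measured in this assay. The change is 4-chlorophenyl in place of 3-methylphenyl on an aromatic nitrogen. Going by the values given here, with no measured step between these two compounds, no size or direction of change can be read from the data; compound 1, which carries a different group at the same place, gives only a limit. Compound 3 is therefore expected to show weak inhibition in this assay, estimated at 100000 nM, within 30000 nM to 300000 nM, and quite possibly only a limit again.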

Compound 3, half-maximal inhibitory concentration: 92000 nM
The estimate for compound 3 lay 1.1-fold (0.04 log units) above the measured number, and the stated range covers the measured number.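

In this assay compound 3 gives 92000 nM, the only true number at this place on the aromatic nitrogen among the compounds shown, and it still stands for weak inhibition. Chloro in place of nitro on an aromatic carbon gives an at least 1.0-fold lower number from compound 1 to compound 3 (0.03 log units; that floor lies within the scatter), so no real change can be claimed, and the comparison has a firm number at only one end: the limit of > 100000 nM in this assay, at which 1 of the 3 values shown sits. Compound 2 has no result, so the swap of 3-methylphenyl for 4-chlorophenyl cannot be read.

As far as these compounds go, how far compound 1 really lies from compound 3 stays unknown. From the compounds shown here alone, it also stays open whether an amine or a carboxylic acid on this aryl ring, or a longer chain in place of the ring, would bring the number down in this assay.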